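The compounds below may be only part of what the source reports. "The series", "measured", "known", "first", "only" and "open" are said of these compounds alone.

Compound 1, `OCC(CO)OCn1cc(I)c2c(NO)ncnc21`: in an ADME assay on HFF cells (Homo sapiens) for cytotoxicity (on this read-out higher numbers stand for weaker inhibition and lower numbers for stronger inhibition), compound 1 gives > 100000 nM, which is a limit of the assay and not a number.

Compound 2, `OCC(CO)OCn1cc(Cl)c2c(NO)ncnc21`: in this assay compound 2 gives > 100000 nM, again a limit of the assay rather than a number.

Going by the values given here, compound 2 therefore stands at the limit, and so does the only other measured compound: both values sit at the limit of > 100000 nM in this assay, at which 2 of the 2 values shown sit. The single measured step, a step that the two limits leave unreadable from compound 1 to compound 2, cannot be read, so the swap of one halogen for another on the shared core has not yet shown any effect that the assay could register.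

Compound 3, `OCC(CO)OCn1cc(Br)c2c(NO)ncnc21`, differs from compound 2 by one change: bromo in place of chloro on an aromatic carbon. Among the compounds with values here, the only measured step that bears on this change is the one from compound 1 to compound 2, a halogen exchange at the same position, and its size is unreadable. There is thus no ground to expect a step beyond the scatter in this assay, in either direction, and the likeliest outcome is another limit.

The step that the limit leaves unreadable from compound 2 to compound 3 is expected to be none beyond the scatter. Compound 3 is accordingly expected to give about 150000 nM, within a range from 50000 nM to 500000 nM.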

Compound 3, half-maximal inhibitory concentration: > 100000 nM
Compound 3 gave a limit, no number; the forecaster's own chance of this, stated with the estimate: 85%; the middle value is on the limit's open side.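

Going by these compounds alone, no step between compound 1, compound 2 and compound 3 can be read, since all three values are limits of the assay and not numbers, and they sit at the same one: the limit of > 100000 nM in this assay, at which 3 of the 3 values shown sit.

Whether iodo, chloro and bromo on the shared core differ at all in this assay stays open, as does the concentration at which any of these compounds would reach half-maximal inhibition.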